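This account rests on a few compounds, and the source may have more. Where it says the series, first, only, none or still open, it means among the compounds named here.

Measured in a functional assay on the whole organism with Rattus norvegicus as the target; on this read-out higher numbers stand for an effect only at larger amounts of compound and lower numbers for an effect already at smaller amounts:
Compound 1 `CCOC(=O)C(=O)Nc1ccc(N)cc1C#N`: 8.8 mg/kg
Compound 2 `CCOC(=O)C(=O)Nc1cccc(NC)c1C#N`: 0.1 mg/kg

Of these two, compound 2 has the lower number at 0.1 mg/kg, and its gap to compound 1 lies beyond the scatter. Compound 3 `CCOC(=O)C(=O)Nc1cccc(C)c1C#N` departs from compound 2 in one place, an aromatic carbon ortho to a cyano group, where it has methyl in place of methylamino (methyl in place of methylamino on an aromatic carbon). Going by the values given here, no measured pair shows what this exchange does, so the expectation is uncertain. With compound 2 already at 0.1 mg/kg, a rise in the number in this assay seems likelier than a further fall. The estimate is a 10-fold higher number from compound 2 to compound 3 (1.00 log units; beyond the scatter), an expected move toward a higher number and beyond the scatter. Compound 3 is expected at 1 mg/kg, with an estimated range of 0.2 mg/kg to 6 mg/kg.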

Compound 3, dose for half-maximal effect: 4.6 mg/kg
Beside the measured number, compound 3's estimate is 4.6-fold (0.66 log units) below it, within the range that was stated.
By their numbers in this assay, from the lowest: compound 2; then compounds 3 and 1 (each within the scatter of the next).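

The aromatic carbon ortho to a cyano group proves to be a sensitive place in this assay: methyl in place of methylamino gives a 46-fold higher number from compound 2 to compound 3 (1.66 log units; beyond the scatter), a large step. Going by these compounds alone, this is the first single-place change, and it shows that the low number of compound 2 does not survive this exchange. The nitrogen leaves with the hydrogen-bond donor and acceptor counted for methylamino, but nothing available explains the step.

Going by these compounds, it remains open whether the nitrogen itself or the whole methylamino group matters, since a primary amine, dimethylamino or methoxy on this carbon would separate these cases. On these data alone, how an ethyl or other longer chain on the nitrogen, or a different ester in place of the ethyl ester, would read in this assay also stays open.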